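Two Methoxy Groups in Place of One

The compounds below may be only part of what the source reports. "The series", "measured", "known", "first", "only" and "open" are said of these compounds alone.

Measured so far:
Compound 1, `COC(=O)/C(=C\c1ccc(OC(=O)c2ccccc2)cc1)Sc1ccnc2cc(Cl)ccc12`: 30200 nM in a functional assay on HL-60 cells (Homo sapiens) for cytotoxicity, read by MTT assay, with a stated time of 24 h; on this read-out lower numbers stand for stronger inhibition and higher numbers for weaker inhibition
Compound 2, `COC(=O)/C(=C\c1ccc(OC(=O)c2ccccc2OC)cc1)Sc1ccnc2cc(Cl)ccc12`: 44500 nM in this assay

Within the data shown here, compound 2 stands at the higher of the two numbers, but its only neighbour is compound 1, and the step of a 1.5-fold higher number from compound 1 to compound 2 (0.17 log units; within the scatter) shows the two cannot be told apart. Compound 3, `COC(=O)/C(=C\c1ccc(OC(=O)c2cc(OC)cc(OC)c2)cc1)Sc1ccnc2cc(Cl)ccc12`, is the next variation: 3,5-dimethoxyphenyl in place of 2-methoxyphenyl on a carbonyl carbon. Among the measured compounds shown here, the one measured step touches the same ring that now leaves, and it changed a hydrogen on that ring into a methoxy without a step beyond the scatter. For the measured compounds named here, no measured pair covers a move of the methoxy to other positions, nor a second methoxy. On that thin basis the expectation for compound 3 is no change beyond the scatter, that is a 1.1-fold lower number from compound 2 to compound 3 (0.05 log units; within the scatter), in the this assay. The estimate for compound 3 is therefore 40000 nM, with a range from 15000 nM to 110000 nM.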

Compound 3, half-maximal inhibitory concentration: 19000 nM
For compound 3 the middle estimate is 2.1-fold (0.32 log units) above the measured one; the measured number falls inside the stated range.
By their numbers in this assay, from the lowest: compounds 3, 1 and 2 (each within the scatter of the next, the first and the last beyond it).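

In this assay, among these compounds, putting 3,5-dimethoxyphenyl in place of 2-methoxyphenyl on this carbonyl carbon gives a 2.3-fold lower number from compound 2 to compound 3 (0.37 log units; beyond the scatter) and is the first step here to clear the usual scatter, which shows that the number can respond, if only modestly, to what the ring on this carbonyl carbon carries. The comparison with the plain phenyl ring is less clear: that change gives a 1.6-fold lower number from compound 1 to compound 3 (0.20 log units; within the scatter), so the one readable difference lies between the two methoxy-bearing rings, while the phenyl compound cannot be told apart from either of them. Nothing available on these compounds accounts for that difference between the two methoxy-bearing rings.

These three compounds cannot separate the number of methoxy groups from where they sit, as the two rings that differ beyond the scatter differ in both at once. From the compounds shown here alone, it also stays open how this assay would read an amine, a hydroxyl or a carboxylic acid on this ring, or a saturated ring such as cyclohexyl in its place, and whether changes elsewhere on the shared core would matter more.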